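Swapping 1H-imidazol-2-yl for 1H-pyrrol-3-yl: working notes

The source may report more compounds than this note shows. Statements on the series, on what has been measured and on what is new or still open speak of the compounds shown alone.

Among the measured compounds shown here, in a functional assay on A-375 cells (Homo sapiens) for activation, with a stated time of 3 days (on this read-out higher numbers stand for an effect only at larger amounts of compound and lower numbers for an effect already at smaller amounts), compound 3 (`O=C(Nc1ccc(-c2ncc[nH]2)cc1)C1CCCN(Cc2ccc(F)c(F)c2)C1`) gives 8000 nM as the higher of the two numbers so far. Compound 2 (`O=C(Nc1ccc(-c2cscn2)cc1)C1CCCN(Cc2cc(F)c(F)c(F)c2)C1`) gives 1260 nM as the lower one, a gap beyond the scatter. Compound 1 (`O=C(Nc1ccc2scnc2c1)C1CCCN(Cc2ccc(F)c(F)c2)C1`) reads > 20000 nM as a limit and not a number. Compound 4 (`O=C(Nc1ccc(-c2cc[nH]c2)cc1)C1CCCN(Cc2ccc(F)c(F)c2)C1`) remains unmeasured, and its change from compound 3 is 1H-pyrrol-3-yl in place of 1H-imidazol-2-yl on an aromatic carbon with 1H-pyrrol-3-yl in place of 1H-imidazol-2-yl on an aromatic carbon. For the measured compounds named here, no measured pair isolates this change. Compound 2 at 1260 nM shows that lower numbers occur in the series, so a modest downward move is expected in this assay and the estimate stays loose. The expected step of a 2.3-fold lower number from compound 3 to compound 4 (0.36 log units; beyond the scatter) is small but just beyond the scatter. For compound 4 the estimated value is 3500 nM within an expected range from 900 nM to 14000 nM on this read-out.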

Compound 4, half-maximal effective concentration: 2610 nM
For compound 4 the middle estimate is 1.3-fold (0.13 log units) above the measured one, within the range that was stated.
By their numbers in this assay, from the lowest: compound 2; then compound 4; then compound 3. At a limit, above all of these: compound 1.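

Among the compounds shown here, the step of a 3.1-fold lower number from compound 3 to compound 4 (0.49 log units; beyond the scatter) in this assay is the first reading of a change in one place, and it shows that this position, para to a large group, responds to the ring attached there. The number does not rise when 1H-pyrrol-3-yl, with 0 hydrogen-bond acceptors, replaces 1H-imidazol-2-yl. Nothing at hand accounts for the size of this step.

Open, as far as these compounds go, is how a methyl group on the pyrrole nitrogen would read here. Also open, from the compounds shown here alone, is how an amine or a carboxylic acid would read on this aromatic carbon.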